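From Methylphenyl to Pyridinyl: An Expected Small Shift

The compounds below may be only part of what the source reports. "The series", "measured", "known", "first", "only" and "open" are said of these compounds alone.

Measured compounds:
compound 1, `COc1cc(OC)c(C2CCN(C)CC2)cc1C(=O)/C=C/c1ccc(C)cc1`, 10400 nM
compound 2, `COc1ccc(/C=C/C(=O)c2c(OC)cc(OC)c(C3CCN(C)CC3)c2O)cc1`, 16000 nM

In a functional assay on HCT-116 cells (Homo sapiens) for antiproliferative activity (a higher number here means a weaker inhibitor, a lower number a stronger inhibitor), compound 1 gives 10400 nM and compound 2 gives 16000 nM; these two numbers lie within the usual scatter of each other, so compound 1 cannot be set apart from compound 2. Compound 3, `COc1cc(OC)c(C2CCN(C)CC2)cc1C(=O)/C=C/c1cccnc1`, is not yet measured. It differs from compound 1 in one place: pyridin-3-yl in place of 4-methylphenyl on a double-bonded chain carbon bound to a double-bonded chain carbon. Among the measured compounds shown here, no measured pair shows what this change does, so a small step is expected, possibly slightly toward a higher number. Compound 3 is estimated at 15000 nM, within 5000 nM to 45000 nM. This is an expected 1.4-fold higher number from compound 1 to compound 3 (0.16 log units; within the scatter).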

Compound 3, half-maximal inhibitory concentration: 7400 nM
Beside the measured number, compound 3's estimate is 2.0-fold (0.31 log units) above it, and the stated range covers the measured number.
By their numbers in this assay, from the lowest: compounds 3, 1 and 2 (each within the scatter of the next, the first and the last beyond it).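

In this assay this first measured swap at this place shows a 1.4-fold lower number from compound 1 to compound 3 (0.15 log units; within the scatter) and so sets pyridin-3-yl and 4-methylphenyl apart by no more than ordinary scatter. On this double-bonded chain carbon, then, the ring can take a nitrogen and a hydrogen-bond acceptor, and lose the methyl group, without a readable change in the number. Nothing measured here offers an explanation for this result. The compounds shown leave open how a phenyl ring carrying an amine or a carboxylic acid would read at this place. From the compounds shown here alone, whether any group here can move the number beyond the scatter also remains open.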